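Benzyl in Place of Fluoropropyl on the Aromatic Nitrogen

The source may report more compounds than this note shows. Statements on the series, on what has been measured and on what is new or still open speak of the compounds shown alone.

Measured compounds:
compound 1, `CCCn1nc(C(=O)N[C@H]2COc3ccccc3N(C)C2=S)nc1Cc1ccccc1`: 288 nM
compound 2, `CN1C(=S)[C@@H](NC(=O)c2nc(Cc3ccccc3)n(CCCF)n2)COc2ccccc21`: 4760 nM
compound 3, `CN1C(=S)[C@@H](NC(=O)c2nc(Cc3ccccc3)n(C3CCOC3)n2)COc2ccccc21`: 1580 nM

In a functional assay on HT-29 cells (Homo sapiens) for inhibition, read by luminescence and CellTiter-Glo, with a stated time of 24 h (a lower number here means that less compound is needed, a higher number that more compound is needed for the effect), compound 2 stands highest of the three numbers, with compound 3 nearest and compound 1 furthest. The step to compound 4, `CN1C(=S)[C@@H](NC(=O)c2nc(Cc3ccccc3)n(Cc3ccccc3)n2)COc2ccccc21`, is phenyl in place of 2-fluoroethyl on a saturated chain carbon bound to an aromatic nitrogen. For the measured compounds named here, two measured steps bear on it. The first, a 17-fold higher number from compound 1 to compound 2 (1.22 log units; beyond the scatter), shows that adding fluorine to the propyl chain gave a large rise; undoing that change in the reverse direction would be a large fall. The second, a 3.0-fold lower number from compound 2 to compound 3 (0.48 log units; beyond the scatter), shows a modest fall when the fluorine-bearing chain is replaced. Both point the same way, so a lower number is expected for compound 4, probably between modest and large. The estimated step is a 7.9-fold lower number from compound 2 to compound 4 (0.90 log units; beyond the scatter). Compound 4 is therefore expected to give about 600 nM in this assay, within a range of 180 nM to 2000 nM.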

Compound 4, half-maximal effective concentration: 414 nM
Estimate against measurement, compound 4: 1.4-fold (0.16 log units) above; low and high end bracket the measured number.
By their numbers in this assay, from the lowest: compounds 1 and 4 (each within the scatter of the next); then compound 3; then compound 2.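

On the aromatic nitrogen in this assay, benzyl in compound 4 gives a large fall from 3-fluoropropyl (an 11-fold lower number from compound 2 to compound 4 (1.06 log units; beyond the scatter)) and a modest fall from oxolan-3-yl (a 3.8-fold lower number from compound 3 to compound 4 (0.58 log units; beyond the scatter)). Benzyl and propyl lie within the scatter of each other (a 1.4-fold higher number from compound 1 to compound 4 (0.16 log units; within the scatter)), so this position accepts an aromatic ring and stays at the level of the plain propyl chain. Nothing available explains these steps. From the compounds shown here alone, whether a pyridine ring, a substituted benzyl or an amine on the chain would hold that level remains open.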